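Amide in Place of Pyridylmethyl on the Ring Nitrogen

The compounds below may be only part of what the source reports. "The series", "measured", "known", "first", "only" and "open" are said of these compounds alone.

Compound 3 `CCCCNc1nc(N)nc2c1CN(Cc1ccncc1)CC2` gives 0.29 uM in an assay on HEK293 cells for agonist activity at Toll-like receptor 8 (Homo sapiens), read by a luciferase reporter, with a stated time of 6 h (on this read-out higher numbers stand for an effect only at larger amounts of compound and lower numbers for an effect already at smaller amounts), the highest of the three numbers, while compound 1 `CCCCNc1nc(N)nc2c1CN(Cc1cccc(Cl)c1Cl)CC2` gives 0.18 uM and compound 2 `CCCCNc1nc(N)nc2c1CN(Cc1ccc(OC)cc1)CC2` gives 0.08 uM. Compound 4 `CCCCNc1nc(N)nc2c1CN(C(=O)c1cc(C)on1)CC2` differs from compound 3 by (5-methyl-1,2-oxazol-3-yl)carbonyl in place of (pyridin-4-yl)methyl on an amine nitrogen in a ring. The measured steps all exchange one aromatic group for another on the same saturated carbon: a 2.3-fold lower number from compound 1 to compound 2 (0.35 log units; beyond the scatter), a 1.6-fold higher number from compound 1 to compound 3 (0.21 log units; within the scatter) and a 3.6-fold higher number from compound 2 to compound 3 (0.56 log units; beyond the scatter). None of them replaces that carbon with a carbonyl, so the change to compound 4 has no close precedent among these compounds. As far as these compounds go, the aromatic exchanges moved the number only modestly, and the carbonyl itself is untested. Compound 4 is therefore expected to show a 3.4-fold higher number from compound 3 to compound 4 (0.54 log units; beyond the scatter), with wide uncertainty. The estimate for compound 4 is 1 uM, within 0.2 uM to 5 uM.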

Compound 4, minimum effective concentration: 0.4 uM
For compound 4 the middle estimate is 2.5-fold (0.40 log units) above the measured one; the measured number falls inside the stated range.
By their numbers in this assay, from the lowest: compound 2; then compounds 1, 3 and 4 (each within the scatter of the next, the first and the last beyond it).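

The exchange of (pyridin-4-yl)methyl for (5-methyl-1,2-oxazol-3-yl)carbonyl on the amine nitrogen in a ring gives a 1.4-fold higher number from compound 3 to compound 4 (0.14 log units; within the scatter) in this assay. This position therefore tolerates a carbonyl in place of the saturated chain carbon, at least with this group attached. The aromatic ring changed in the same step, so the effects of the carbonyl and the ring cannot be told apart, and no measurement shown explains the result.

As far as these compounds go, it remains open how a 4-methoxybenzoyl group, which would keep the ring of compound 2 on a carbonyl, would behave here. A small acetyl group on the same nitrogen is also an open case.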